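Swapping the core of compound 2 for a new fused ring

This account rests on a few compounds, and the source may have more. Where it says the series, first, only, none or still open, it means among the compounds named here.

Four compounds share one long side chain and differ only in the core bound to the amide carbonyl. Compound 1 `Cc1ccn2nc(C)c(C(=O)NCc3ccc(N4CCC(c5ccc(OC(F)(F)F)cc5)CC4)cc3)c2n1` and compound 2 `Cc1nn2ccc(=O)[nH]c2c1C(=O)NCc1ccc(N2CCC(c3ccc(OC(F)(F)F)cc3)CC2)cc1` have no result in a toxicity assay on Vero cells (Chlorocebus sabaeus) for cytotoxicity, read by CCK-8 assay, with a stated time of 72 h; a lower number here means a stronger inhibitor, a higher number a weaker inhibitor: compound 1 is recorded as "not determined" (no result reported) and compound 2 as "not determined" (no result reported). For compound 3 `Cc1nc2scc(C)n2c1C(=O)NCc1ccc(N2CCC(c3ccc(OC(F)(F)F)cc3)CC2)cc1` only a limit of this assay is known; in this assay compound 3 shows > 100000 nM. So compound 2 stands without a number of its own, and its only measured companion sits at the limit of > 100000 nM in this assay, at which 1 of the 3 values shown sits. Compound 4 `Cc1cn2nc(C)c(C(=O)NCc3ccc(N4CCC(c5ccc(OC(F)(F)F)cc5)CC4)cc3)c2s1` differs from compound 2 in one place: a group of 10 heavy atoms (7 carbon, 2 nitrogen, 1 sulfur; 2 five-membered aromatic rings with 2 hetero atoms each) in place of a group of 11 heavy atoms (7 carbon, 3 nitrogen, 1 oxygen; one five-membered aromatic ring with 2 hetero atoms, one six-membered aromatic ring with 2 hetero atoms), on a carbonyl carbon. Because compound 3 rests at the limit of > 100000 nM in this assay, at which 1 of the 3 values shown sits, a limit rather than a number is the likely outcome for compound 4 as well. Compound 4 is expected to give about 100000 nM, between 30000 nM and 300000 nM.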

Compound 4, half-maximal inhibitory concentration: > 100000 nM
Compound 4 gave a limit, no number; the forecaster's own chance of this, stated with the estimate: 80%; the middle value lies on the limit itself.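

Compound 3 and compound 4 both rest on a limit of the assay rather than a number, so no step between them can be read: the limit of > 100000 nM in this assay, at which 2 of the 4 values shown sit.

The compounds shown leave open how compound 2 compares with compound 4, and whether the cores of compound 3 and compound 4 differ at all.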